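The compounds below may be only part of what the source reports. "The series", "measured", "known", "first", "only" and "open" are said of these compounds alone.

Measured compounds in an ADME assay on HepG2 cells (Homo sapiens) for cytotoxicity, read by luminescence, CellTiter-Glo and ATP content, with a stated time of 72 h; on this read-out lower numbers stand for an effect already at smaller amounts and higher numbers for an effect only at larger amounts of compound:

compound 1 `COc1cccc(CNCCCNc2ccnc3cc(-c4ccc(F)cc4)ccc23)c1O`: 6840 nM
compound 2 `COc1cccc(CNCCCNc2ccnc3cc(Cc4cccc(C(F)(F)F)c4)ccc23)c1O`: 1720 nM
compound 3 `COc1ccccc1Oc1ccc2c(NCCCNCc3cccc(OC)c3O)ccnc2c1`: 11200 nM

Compound 3 gives the highest number of the three in this assay. Its nearest neighbour is compound 1, with a 1.6-fold higher number from compound 1 to compound 3 (0.21 log units; within the scatter). Its furthest is compound 2, with a 6.5-fold higher number from compound 2 to compound 3 (0.81 log units; beyond the scatter).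

Compound 4 `COc1cccc(CNCCCNc2ccnc3cc(-c4cccc5ccccc45)ccc23)c1O` has not yet been measured. It differs from compound 3 in one place: naphthalen-1-yl in place of 2-methoxyphenoxy on an aromatic carbon. The group that enters is bonded straight to the shared core, as 4-fluorophenyl is in compound 1, whereas 2-methoxyphenoxy in compound 3 is joined through an oxygen.

Within the data shown here, two measured steps bear on this. Swapping 4-fluorophenyl for 2-methoxyphenoxy gave a 1.6-fold higher number from compound 1 to compound 3 (0.21 log units; within the scatter), a change within the scatter. Swapping 3-(trifluoromethyl)benzyl for 2-methoxyphenoxy gave a 6.5-fold higher number from compound 2 to compound 3 (0.81 log units; beyond the scatter), beyond the scatter. Since compound 4 resembles compound 1 in how its ring attaches, the step to compound 4 is expected to be small, perhaps a slightly lower number, as a 2.0-fold lower number from compound 3 to compound 4 (0.31 log units; beyond the scatter). Compound 4 is therefore estimated at 5500 nM, within a range of 2000 nM to 15000 nM.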

Compound 4, half-maximal effective concentration: 2520 nM
Beside the measured number, compound 4's estimate is 2.2-fold (0.34 log units) above it; low and high end bracket the measured number.
By their numbers in this assay, from the lowest: compounds 2 and 4 (each within the scatter of the next); then compounds 1 and 3 (each within the scatter of the next).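

In this assay, a group bonded straight to the shared core does not by itself set the number at this position: naphthalen-1-yl in place of 4-fluorophenyl gives a 2.7-fold lower number from compound 1 to compound 4 (0.43 log units; beyond the scatter), so two directly bonded groups can differ beyond the scatter. Naphthalen-1-yl in place of 2-methoxyphenoxy gives a 4.4-fold lower number from compound 3 to compound 4 (0.65 log units; beyond the scatter), a shift beyond the scatter. In place of 3-(trifluoromethyl)benzyl it gives a 1.5-fold higher number from compound 2 to compound 4 (0.17 log units; within the scatter), so two groups joined to the core in different ways can still fall within the scatter of each other.

On these data alone, how an amine or a carboxylic acid at this position would shift the number remains open. The compounds shown cannot separate the effect of the second fused ring from that of the link to the core, and no measurement here explains these shifts.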